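The compounds below may be only part of what the source reports. "The series", "measured", "known", "first", "only" and "open" are said of these compounds alone.

Measured compounds:
Compound 1, `NS(=O)(=O)c1ccc(-n2ncc3c(=O)[nH]c(-c4ccccc4)nc32)cc1` — in a functional assay on MCF7 cells (Homo sapiens) for cytotoxicity, read by MTT assay, with a stated time of 72 h (on this read-out higher numbers stand for weaker inhibition and lower numbers for stronger inhibition), compound 1 gives > 100000 nM, a limit of the assay rather than a number.
Compound 2, `NS(=O)(=O)c1ccc(-n2ncc3c(=O)[nH]c(-c4ccc(F)cc4)nc32)cc1` — in this assay compound 2 gives 38000 nM.

Going by the values given here, compound 2 therefore holds the only real number in this assay so far; the other value is a limit. Compound 3, `NS(=O)(=O)c1ccc(-n2ncc3c(=O)[nH]c(-c4ccc(Cl)cc4)nc32)cc1`, differs from compound 2 by chloro in place of fluoro on an aromatic carbon. Among the compounds with values here, only one measured step touches this position: an at least 2.6-fold lower number from compound 1 to compound 2 (0.42 log units; beyond the scatter), which placed a halogen on the same aromatic carbon. Its true size is uncertain because compound 1 sits at the limit of > 100000 nM in this assay, at which 1 of the 2 values shown sits. Swapping one halogen for another at the same place is a smaller change than adding one where none was, so a step of a 1.5-fold lower number from compound 2 to compound 3 (0.18 log units; within the scatter) is expected, small enough that it may fall within the scatter. Compound 3 is estimated at 25000 nM, with a range from 8000 nM to 80000 nM.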

Compound 3, half-maximal inhibitory concentration: 2500 nM
The estimate for compound 3 lay 10-fold (1.00 log units) above the measured number, outside the stated range (below it).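

Which halogen sits on this aromatic carbon matters in this assay, not only whether one is present: chloro in place of fluoro gives a 15-fold lower number from compound 2 to compound 3 (1.18 log units; beyond the scatter). Compared with hydrogen, chloro gives an at least 40-fold lower number from compound 1 to compound 3 (1.60 log units; beyond the scatter), so compound 3 now has the lowest number of the three, with its steps to both others beyond the scatter. From the compounds shown here alone, the true size of that second step remains unknown because compound 1 gives a limit rather than a real number: the limit of > 100000 nM in this assay, at which 1 of the 3 values shown sits.

The compounds shown leave open whether the numbers keep falling with bromo at this place, or whether the drop belongs to halogens at all. A methyl, a methoxy or an amine on the same carbon could match chloro or could fall back towards hydrogen, and these three compounds cannot tell which.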